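The compounds below may be only part of what the source reports. "The series", "measured", "known", "first", "only" and "open" are said of these compounds alone.

Measured compounds:
compound 1 `CC(C)n1nc(S(=O)(=O)c2cccc3ccccc23)c2cc(N3CCN(C)CC3)ccc21` — 1.8 nM
compound 2 `CN1CCN(c2ccc3[nH]nc(S(=O)(=O)c4ccccc4Cl)c3c2)CC1` — 4 nM

In an assay on HeLa cells for displacement of a labelled ligand from 5-hydroxytryptamine receptor 6 (Homo sapiens) (on this read-out lower numbers stand for stronger inhibition and higher numbers for weaker inhibition), compound 1 gives 1.8 nM, the lower of the two numbers shown, while compound 2 gives 4 nM, a gap that lies beyond the usual scatter. Compound 3 `CC(C)Cn1nc(S(=O)(=O)c2cccc3ccccc23)c2cc(N3CCN(C)CC3)ccc21` has not been measured; it differs from compound 1 by isobutyl in place of isopropyl on an aromatic nitrogen. Going by the values given here, no measured pair shows this kind of change, so the step from compound 1 to compound 3 is expected to stay within the scatter, with the estimate a 1.4-fold higher number from compound 1 to compound 3 (0.14 log units; within the scatter). For compound 3 the expected value in this assay is 2.5 nM, within a range from 1 nM to 6 nM.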

Compound 3, inhibition constant: 1.4 nM
The estimate for compound 3 lay 1.8-fold (0.25 log units) above the measured number; the measured number falls inside the stated range.
By their numbers in this assay, from the lowest: compounds 3 and 1 (each within the scatter of the next); then compound 2.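

In this assay, isobutyl in place of isopropyl on an aromatic nitrogen gives a 1.3-fold lower number from compound 1 to compound 3 (0.11 log units; within the scatter) and so stays within the scatter. This is the first step shown at this position, and it shows that the nitrogen carries the branched chain of 4 carbon atoms as well as the one of 3. Nothing available accounts for this result.

As far as these compounds go, whether that holds for a longer chain, a benzyl group or a chain ending in an amine remains open. Compound 2 differs from compound 1 in more than one place, so it cannot show what the isopropyl group itself contributes.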